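Hydroxy to acetyl on the side chain: an expected step

This account rests on a few compounds, and the source may have more. Where it says the series, first, only, none or still open, it means among the compounds named here.

Compound 1, `CCCn1c(=O)n(CCC(=O)O)c(=O)c2[nH]cnc21`, in an assay on Cerebral cortex for binding affinity to adenosine receptor A1 (Cavia porcellus), read by radioligand binding (on this read-out higher numbers stand for weaker inhibition and lower numbers for stronger inhibition), gives > 200000 nM, which is a limit of the assay rather than a number.
Compound 2, `CCCn1c(=O)n(CCO)c(=O)c2[nH]cnc21`, gives 50000 nM.

Among the measured compounds shown here, compound 2 thus holds the only actual number; the other value sits at a limit (the limit of > 200000 nM in this assay, at which 1 of the 2 values shown sits). Compound 3, `CCCn1c(=O)n(CCC(C)=O)c(=O)c2[nH]cnc21`, differs from compound 2 by acetyl in place of hydroxy on a saturated chain carbon, two bonds along the chain from an aromatic nitrogen. For the measured compounds named here, the only measured step, an at least 4.0-fold lower number from compound 1 to compound 2 (0.60 log units; beyond the scatter), concerns a different group at that place and bears on this change only loosely. A small shift is expected, a 1.7-fold lower number from compound 2 to compound 3 (0.22 log units; within the scatter). Compound 3 is estimated at 30000 nM, within 8000 nM to 150000 nM.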

Compound 3, inhibition constant: 11200 nM
Compound 3: middle estimate off by 2.7-fold (0.43 log units), on the high side; the range from low to high includes it.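

Acetyl does more at this place than the small shift expected: the data show a 4.5-fold lower number from compound 2 to compound 3 (0.65 log units; beyond the scatter) in this assay and rank it ahead of hydroxy. Both compound 1 and compound 3 carry a carbonyl on the chain, yet methyl in place of hydroxy on that carbonyl carbon gives an at least 17-fold lower number from compound 1 to compound 3 (1.25 log units; beyond the scatter), so a carbonyl alone does not set the value. The value of compound 1 is a limit, so this step gives only a minimum size: the limit of > 200000 nM in this assay, at which 1 of the 3 values shown sits.

An amine, an amide or a longer chain ending in a ketone could show whether the gain belongs to the acetyl group itself.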